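A few compounds are considered here, and "the series" means these few. Any claim that something is new, unique, unknown or untested is made for them only; others in the source may bear on it.

Measured compounds:
compound 1, `CC1=C(C(=O)OC(C)(C)C)C(c2cccs2)NC(=O)N1`: 26%
compound 2, `CC1=C(C(=O)OC2CCCCC2)C(c2cccs2)NC(=O)N1`: 7%

In an assay on membranes from CHO cells for displacement of a labelled ligand from adenosine receptor A1 (Homo sapiens), read by scintillation counting, with a stated time of 60 min, tested at 1 uM (on this read-out higher numbers stand for more inhibition at the one concentration tested (going by the name of the read-out) and lower numbers for less inhibition), compound 2 gives 7% and stands lowest of the two numbers; the nearest is compound 1, which gives 26%. Going by the values given here, the one measured step, a number 19 percentage points lower from compound 1 to compound 2 (beyond the scatter), is the exchange of tert-butyl for cyclohexyl on an oxygen next to a carbonyl group, and it lies beyond the scatter.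

Compound 3, `CC1=C(C(=O)OCC2CCC2)C(c2cccs2)NC(=O)N1`, has not been measured. It differs from compound 2 by cyclobutylmethyl in place of cyclohexyl on an oxygen next to a carbonyl group. The only step on record concerns the same oxygen, so it bears on this change, but it compares two other groups; a drop was seen when cyclohexyl entered in place of tert-butyl, and cyclobutylmethyl is a third group whose effect is not shown. Compound 3 is therefore expected to give a number close to compound 2, a change of a number 5 percentage points higher from compound 2 to compound 3 (within the scatter), within or only slightly beyond the scatter. The estimate for compound 3 is 12%, in the range 0% to 28%.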

Compound 3, a percentage reported as inhibition, at one concentration (the size of the read-out at that concentration, not a potency): 39%
Estimate against measurement, compound 3: 27 percentage points below; measured number above the stated range.
By their numbers in this assay, from the lowest: compound 2; then compound 1; then compound 3.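

In this assay, cyclobutylmethyl in place of cyclohexyl on an oxygen next to a carbonyl group gives a number 32 percentage points higher from compound 2 to compound 3 (beyond the scatter), and cyclobutylmethyl in place of tert-butyl gives a number 13 percentage points higher from compound 1 to compound 3 (beyond the scatter). The earlier step showed only a fall at this oxygen, whereas these steps show that exchange of the group there can also raise the number, and compound 3 stands highest of the three, with both of its steps beyond the scatter. Nothing on hand accounts for this order.

The compounds shown leave open whether the rise belongs to the four-membered ring or to the carbon that links it to the oxygen, which cyclobutyl or cyclohexylmethyl would help to separate. They also leave open how an amine or a carboxylic acid at the end of a longer chain would read out at this oxygen.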